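From Ethylcarbamoyl to an Arylsulfonyl Group on Nitrogen

The compounds below may be only part of what the source reports. "The series", "measured", "known", "first", "only" and "open" are said of these compounds alone.

- Compound 1 `CCNC(=O)Nc1nc(-c2ccc(OCC)cc2)c(-c2cc(OC)c(OC)c(OC)c2)s1` gives 29.2 nM
- Compound 2 `CCOc1ccc(-c2nc(N(Cc3ccccc3)Cc3ccccc3)sc2-c2cc(OC)c(OC)c(OC)c2)cc1` gives > 5000 nM (a limit of the assay, not a number)

Among the measured compounds shown here, in a functional assay on SK-OV-3 cells (Homo sapiens) for antiproliferative activity, read by MTT assay, with a stated time of 48 h (a higher number here means a weaker inhibitor, a lower number a stronger inhibitor), compound 1 gives 29.2 nM, which is the only true number so far. Compound 2 reaches only a limit, > 5000 nM, so it offers no exact value for comparison. The two results nevertheless show that compounds of this family need not all sit near compound 1 in this assay.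

Compound 3 `CCOc1ccc(-c2nc(NS(=O)(=O)c3ccc(OC)c(F)c3)sc2-c2cc(OC)c(OC)c(OC)c2)cc1` has not yet been measured. It carries (3-fluoro-4-methoxyphenyl)sulfonyl in place of ethylcarbamoyl on a nitrogen on an aromatic ring. For the measured compounds named here, no measured step between two closely matched compounds is available, so any forecast here is loose. Since compound 1 at 29.2 nM has a low starting value, and a replacement of this size is a large change, a shift toward weaker inhibition, beyond the usual scatter, is expected. The expected size is a 14-fold higher number from compound 1 to compound 3 (1.14 log units; beyond the scatter). For compound 3 the estimated value is 400 nM, with an expected range from 40 nM to 4000 nM.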

Compound 3, half-maximal inhibitory concentration: > 5000 nM
Compound 3: no number, only a limit (the forecaster's own chance of this, stated with the estimate: 15%); middle value at least 12-fold (1.09 log units) away from the limit.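

Among the compounds shown here, on a nitrogen on an aromatic ring, putting (3-fluoro-4-methoxyphenyl)sulfonyl in place of ethylcarbamoyl gives an at least 170-fold higher number from compound 1 to compound 3 (2.23 log units; beyond the scatter) in this assay, and this is the first change in one place that can be read in this set. Compound 3 gives > 5000 nM, which is a limit of the assay and not a number, so the step sets a lower bound on the change and not its exact size. It shows that the strength of compound 1 does not survive this swap on the nitrogen, but the real gap stays unknown because compound 3 sits at the limit, as other values here do: the limit of > 5000 nM in this assay, at which 2 of the 3 values shown sit.

The compounds shown cannot say which part of the new group goes with the weaker result: the sulfonyl link, the aromatic ring it carries, or the fluorine and methoxy on that ring. A small methylsulfonyl group, an unsubstituted phenylsulfonyl group, or a propylcarbamoyl group on the same nitrogen would help to separate these parts, and would show how much room this position allows around the ethylcarbamoyl of compound 1.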